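A few compounds are considered here, and "the series" means these few. Any claim that something is new, unique, unknown or untested is made for them only; others in the source may bear on it.

In a functional assay on A2780 cells (Homo sapiens) for antiproliferative activity, read by MTT assay, with a stated time of 48 h (a higher number here means a weaker inhibitor, a lower number a stronger inhibitor), compound 1 `COc1ccc2c(/C=C/C(=O)c3cc(OC)c(OC)c(SC)c3)c[nH]c2c1` gives 139 nM and compound 2 `COc1ccc2c(/C=C/C(=O)c3cc(N)c(OC)c(OC)c3)c[nH]c2c1` gives 204 nM. For the measured compounds named here, these two values cannot be told apart, so compound 1 stands level with the only other measured compound. Compound 3 `COc1cc(C(=O)/C=C/c2c[nH]c3ccccc23)cc(SC)c1OC` differs from compound 1 at a single place: hydrogen in place of methoxy on an aromatic carbon. In words, this is hydrogen in place of methoxy on an aromatic carbon. Going by the values given here, the one measured step, a 1.5-fold higher number from compound 1 to compound 2 (0.17 log units; within the scatter), comes from amino in place of methylsulfanyl, and compound 2 keeps the methoxy that compound 3 loses. That step therefore shows a different change and gives only weak guidance here. Among the compounds with values here, no measurement yet shows what removing this methoxy does, so any forecast must stay loose. A modest rise in the number is expected, with the estimated step being a 2.5-fold higher number from compound 1 to compound 3 (0.40 log units; beyond the scatter). For compound 3, the estimated value is 350 nM, with an expected range from 100 nM to 1200 nM.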

Compound 3, half-maximal inhibitory concentration: 169 nM
Compound 3: middle estimate off by 2.1-fold (0.32 log units), on the high side; measured number inside the range.
By their numbers in this assay, from the lowest: compounds 1, 3 and 2 (each within the scatter of the next).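

In this assay, for the compounds shown here, putting hydrogen in place of the methoxy on this aromatic carbon of the fused two-ring system gives a 1.2-fold higher number from compound 1 to compound 3 (0.08 log units; within the scatter), the first direct reading of this position. Compound 1 and compound 3 therefore stand level, so in this compound, which carries methylsulfanyl, this methoxy is not needed to keep the number at the level of compound 1. No measurement on hand offers a reason for this result.

Only hydrogen is shown as a replacement here, so it stays open whether a hydroxyl group, a fluorine atom or a longer chain such as ethoxy would also leave the number level. As far as these compounds go, it is equally open whether losing this methoxy would read the same in compound 2, which carries amino in place of methylsulfanyl.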